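From a (4-fluorophenyl)amino amide to a dimethylamino amide

This account rests on a few compounds, and the source may have more. Where it says the series, first, only, none or still open, it means among the compounds named here.

Compound 2 `N#CC1(NC(=O)[C@@H]2C[C@@H](S(=O)(=O)c3ccccc3)C[C@H]2C(=O)Nc2ccc(F)cc2)CC1` gives 26 nM in an assay on isolated protein for inhibition of cathepsin S (Homo sapiens), read by fluorescence, with a stated time of 20 min (a higher number here means a weaker inhibitor, a lower number a stronger inhibitor), the highest of the two numbers recorded so far. For the measured compounds named here, compound 1 `N#CC1(NC(=O)[C@@H]2C[C@@H](S(=O)(=O)c3ccccc3)C[C@H]2C(=O)N2CC3(COC3)C2)CC1` gives 3 nM in this assay, and the step of an 8.7-fold higher number from compound 1 to compound 2 (0.94 log units; beyond the scatter) is the only measured change, the one in which the (4-fluorophenyl)amino group entered on the carbonyl carbon. Compound 3 `CN(C)C(=O)[C@@H]1C[C@H](S(=O)(=O)c2ccccc2)C[C@H]1C(=O)NC1(C#N)CC1` differs from compound 2 at the same carbonyl carbon: dimethylamino in place of (4-fluorophenyl)amino on a carbonyl carbon. Going by the values given here, no measured step covers this exact exchange, but the one comparison available shows compound 2 as the weaker partner once the (4-fluorophenyl)amino group is present, so its removal in favour of a small group without a ring is expected to lower the number again, though not necessarily all the way back to compound 1. For compound 3 the expected value in this assay is 8 nM, with a range of 3 nM to 25 nM, an expected step of a 3.3-fold lower number from compound 2 to compound 3 (0.51 log units; beyond the scatter).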

Compound 3, half-maximal inhibitory concentration: 6 nM
Beside the measured number, compound 3's estimate is 1.3-fold (0.12 log units) above it; low and high end bracket the measured number.
By their numbers in this assay, from the lowest: compounds 1 and 3 (each within the scatter of the next); then compound 2.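

Exchanging (4-fluorophenyl)amino for dimethylamino on this carbonyl carbon gives a 4.3-fold lower number from compound 2 to compound 3 (0.64 log units; beyond the scatter) in this assay, so a group with no ring can serve at this place, where only groups with rings had been seen before. The comparison with the other ring-bearing group, a 2.0-fold higher number from compound 1 to compound 3 (0.30 log units; within the scatter), places dimethylamino level with the group of compound 1, so the two four-membered rings of compound 1 are not required for a number in this range. No supporting data accompany these steps, and the reason for them stays unexplained.

The compounds shown leave open how far this tolerance extends, for example to a plain amino group, to diethylamino with its longer chains, or to morpholine. They also leave open whether the loss seen with compound 2 comes with other aryl amides, such as an unsubstituted phenylamino group.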